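A few compounds are considered here, and "the series" means these few. Any claim that something is new, unique, unknown or untested is made for them only; others in the source may bear on it.

Measured in an ADME assay for pharmacokinetics, at pH 7.4 (on this read-out lower numbers stand for a shorter-lived compound and higher numbers for a longer-lived compound), are three compounds:
- compound 1 `COc1ccnc(C[S+]([O-])c2nc3cc(OC(F)F)ccc3[nH]2)c1` with 51 h
- compound 2 `COc1ccnc(C[S+]([O-])c2nc3cc(OC(F)F)ccc3[nH]2)c1C` with 3 h
- compound 3 `COc1ccnc(C[S+]([O-])c2nc3cc(OCC(F)(F)F)ccc3[nH]2)c1C` with 5 h

Compound 2 sits at the low end of these numbers, within the scatter of compound 3. Compound 4 `COc1cc2[nH]c([S+]([O-])Cc3nccc(OC)c3C)nc2cc1OC(F)F` departs from compound 2 by one change (methoxy in place of hydrogen on an aromatic carbon), methoxy in place of hydrogen on an aromatic carbon. The nearest measured change, methyl in place of hydrogen on an aromatic carbon, gave the large step of a 17-fold lower number from compound 1 to compound 2 (1.23 log units; beyond the scatter) but involves a different group. Swapping 2,2,2-trifluoroethyl for difluoromethyl gave only a 1.7-fold higher number from compound 2 to compound 3 (0.22 log units; within the scatter) within the scatter. Among the measured compounds shown here, no measured step tests methoxy, so no shift beyond the scatter is expected, and the estimated step is no change at the digits printed from compound 2 to compound 4 (within the scatter) in either direction. For compound 4 the estimate is 3 h with an expected range from 1.2 h to 8 h here.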

Compound 4, half-life: 11 h
The estimate for compound 4 lay 3.7-fold (0.56 log units) below the measured number; the measured number lies above the stated range.
By their numbers in this assay, from the lowest: compounds 2 and 3 (each within the scatter of the next); then compound 4; then compound 1.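

In this assay, methoxy in place of hydrogen on the six-membered aromatic ring of carbon only, ortho to the difluoromethoxy group, gave a 3.7-fold higher number from compound 2 to compound 4 (0.56 log units; beyond the scatter) and so showed that this position can respond to substitution. The earlier steps shown here left this position unchanged, and the only one beyond the scatter, a 17-fold lower number from compound 1 to compound 2 (1.23 log units; beyond the scatter) at a different place, ran in the opposite direction. Nothing available bears on why the number rose. Still open, as far as these compounds go, is whether an ethoxy group or an amine here would move the number likewise, and whether methoxy would do so alongside 2,2,2-trifluoroethyl on the oxygen.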